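This account rests on a few compounds, and the source may have more. Where it says the series, first, only, none or still open, it means among the compounds named here.

Measured in a functional assay on cells (Platelet, Homo sapiens) for inhibition; on this read-out lower numbers stand for stronger inhibition and higher numbers for weaker inhibition:
- compound 1 `CCOC(=O)c1ccc(-c2nn(C)c3ccccc23)cc1`: > 10000 nM
- compound 2 `CCOC(=O)c1ccc(-c2nn(CC)c3ccccc23)cc1`: > 10000 nM
- compound 3 `O=C(O)c1ccc(-c2nn(Cc3ccccc3)c3ccccc23)cc1`: > 10000 nM

Each of these entries is a limit of the assay and not a number.

Compound 3 therefore has no exact place on the scale. It stands at > 10000 nM, which is a limit. The other two compounds offer no number to compare it with, as the whole set sits together: the limit of > 10000 nM in this assay, at which 3 of the 3 values shown sit.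

Compound 4 `CC(C)NC(=O)c1ccc(-c2nn(Cc3ccccc3)c3ccccc23)cc1` is made from compound 3 by one change, with isopropylamino in place of hydroxy on a carbonyl carbon. The same difference can be read as carboxy to isopropylcarbamoyl.

Within the data shown here, only one step has been measured, a step that the two limits leave unreadable from compound 1 to compound 2. Among the measured compounds shown here, it concerns a different change and gives no size, so no measured step bears on this one. Any readable change can only run toward stronger inhibition, since compound 3 holds > 10000 nM, a limit. A result at the limit again remains quite likely, so only a modest shift is expected.

The step expected in this assay is an at least 1.4-fold lower number from compound 3 to compound 4 (0.15 log units; that floor lies within the scatter). For compound 4 the estimated value is 7000 nM, with an expected range from 2000 nM to 10000 nM.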

Compound 4, half-maximal inhibitory concentration: > 10000 nM
Compound 4 gave a limit, no number; the forecaster's own chance of this, stated with the estimate: 60%; middle value at least 1.4-fold (0.15 log units) away from the limit.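

In this assay compound 4 gives > 10000 nM, which is a limit and not a number. No size can therefore be read for the change from compound 3 to compound 4. The compounds shown leave open which change to the shared core, if any, would give a measurable value, as the whole set sits together: the limit of > 10000 nM in this assay, at which 4 of the 4 values shown sit.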